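Hexylamino to hydroxypropylamino on the fluorobenzyl compound

The source may report more compounds than this note shows. Statements on the series, on what has been measured and on what is new or still open speak of the compounds shown alone.

Compound 1 `CCCCCCNc1nc(-c2ccccc2)nc2c1nnn2Cc1ccccc1` is the parent of the set and in an assay on Cerebral cortex for displacement of a labelled ligand from adenosine receptor A1 (Bos taurus) (on this read-out higher numbers stand for weaker inhibition and lower numbers for stronger inhibition), compound 1 gives 13.2 nM. Compound 2 `CCCCCCNc1nc(-c2ccccc2)nc2c1nnn2Cc1ccccc1F` carries fluoro in place of hydrogen on an aromatic carbon of the benzyl group; in this assay compound 2 gives 25 nM, and the step of a 1.9-fold higher number from compound 1 to compound 2 (0.28 log units; within the scatter) stays within the scatter. Compound 3 `CCCCCCNc1nc(-c2ccccc2)nc2c1nnn2Cc1ccccc1C(F)(F)F` has a trifluoromethyl at the same ring carbon, but in this assay compound 3 gives "not determined" (no result reported), so it has no result. Among the two numbers available, compound 2 has the higher one, with compound 1 nearest to it and separated by a step within the scatter; compound 3 adds no number.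

Compound 4 `CC(O)CNc1nc(-c2ccccc2)nc2c1nnn2Cc1ccccc1F` differs from compound 2 at the other end of the molecule: 1-hydroxyethyl in place of pentyl on a saturated chain carbon bound to a nitrogen on an aromatic ring. Put differently, the hexyl chain on the amine becomes 2-hydroxypropyl. Among the compounds with values here, neither measured step touches this chain; the only step available, the change at the benzyl ring from compound 1 to compound 2, is within the scatter and gives no guide to a change on the amine side. The chain is shortened and gains a hydroxyl, and for compound 4 the number in this assay is expected to rise, estimated at 250 nM with a range of 60 nM to 1500 nM. The step this implies, a 10-fold higher number from compound 2 to compound 4 (1.00 log units; beyond the scatter), is expected to lie beyond the scatter.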

Compound 4, inhibition constant: 4.8 nM
The estimate for compound 4 lay 52-fold (1.72 log units) above the measured number; measured number below the stated range.
By their numbers in this assay, from the lowest: compound 4; then compounds 1 and 2 (each within the scatter of the next).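

In this assay, within the data shown here, the amine side is the first place where a single change gives a step beyond the scatter: hexyl to 2-hydroxypropyl gives a 5.2-fold lower number from compound 2 to compound 4 (0.72 log units; beyond the scatter). Among these compounds, the only earlier step, at the benzyl group, could not show this, and the new step shows that the full hexyl chain is not needed for a low number on the fluorobenzyl compound, since the smaller 1-hydroxyethyl, with its hydrogen-bond donor and acceptor, is accepted in place of pentyl. No independent measurement is at hand to explain the drop in the number.

From the compounds shown here alone, the chain was shortened and gained a hydroxyl in the same step, so the contribution of each remains open; a plain propyl chain and a hexyl chain carrying a hydroxyl would separate the two. Also open, going by these compounds, is whether the same change holds with the unsubstituted benzyl group of compound 1, and whether an amine or a carboxylic acid in place of the hydroxyl would be accepted on this chain.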